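Removing the Last Chloro Group from Compound 2

A few compounds are considered here, and "the series" means these few. Any claim that something is new, unique, unknown or untested is made for them only; others in the source may bear on it.

In a functional assay on MDA-MB-231 cells (Homo sapiens) for antiproliferative activity, read by MTT assay, with a stated time of 72 h (a lower number here means a stronger inhibitor, a higher number a weaker inhibitor), compound 1 `COc1cc(CCc2ccc(Cl)c(Cl)c2)cc(OC)c1O` gives 2520 nM. Compound 2 `COc1cc(CCc2ccc(Cl)cc2)cc(OC)c1O` carries one chloro fewer than compound 1. In this assay compound 2 reaches only a limit of the assay, > 25000 nM, and not a number. Compound 3 `COc1cc(CCc2ccc(Cl)cc2Cl)cc(OC)c1O` likewise gives only a limit, > 25000 nM, in this assay. Compound 2 therefore stands at the upper edge of the numbers shown, at the limit of > 25000 nM in this assay, at which 2 of the 3 values shown sit. The step of an at least 9.9-fold higher number from compound 1 to compound 2 (0.99 log units; beyond the scatter) shows that losing one chloro made a clearly weaker inhibitor, while the step that the two limits leave unreadable from compound 2 to compound 3 cannot be read because both of its ends are limits.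

Compound 4 `COc1cc(CCc2ccccc2)cc(OC)c1O` takes the remaining chloro away: hydrogen in place of chloro on an aromatic carbon. For the measured compounds named here, the one readable step, an at least 9.9-fold higher number from compound 1 to compound 2 (0.99 log units; beyond the scatter), points the same way as this change, so compound 4 is expected to be no stronger than compound 2 and most likely to be reported again as a limit. The estimate for compound 4 in this assay is 50000 nM, within a range from 15000 nM to 200000 nM. This estimate amounts to an expected step that the limit leaves unreadable from compound 2 to compound 4.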

Compound 4, half-maximal inhibitory concentration: > 25000 nM
Compound 4 gave a limit, no number; the forecaster's own chance of this, stated with the estimate: 85%; the middle value lies beyond the limit too.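

Compound 2 and compound 4 each give only a limit of the assay in this assay, so no new step can be read between them: the limit of > 25000 nM in this assay, at which 3 of the 4 values shown sit. The compounds shown leave open how strongly compound 2, compound 3 and compound 4 act, and whether removing the last chloro changes anything in this assay.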